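The source may hold more compounds than are shown below. What is called first, only, known or untested is meant among the compounds shown, and "the series" means these compounds.

Measured so far:

Compound 1, `O=C(O)c1cccc(CNc2cc(C(F)(F)F)cc3[nH]ncc23)c1`, gives 1690 nM in an assay for inhibition of Tryptophan 2,3-dioxygenase (Homo sapiens), with stated times of 10 min and 60 min; a higher number here means a weaker inhibitor, a lower number a stronger inhibitor.
Compound 2, `Cc1ccc(CNc2cc(C(F)(F)F)cc3[nH]ncc23)c([N+](=O)O)c1`, gives 620 nM in this assay.
Compound 3, `O=[N+](O)c1c(Cl)cccc1CNc1cc(C(F)(F)F)cc2[nH]ncc12`, gives 170 nM in this assay.

Among these three, compound 2 holds the second highest number. Compound 1 sits nearest to it, with a higher number, and that gap lies beyond the usual scatter; compound 3 lies furthest from it, with a lower number, and that gap too lies beyond the scatter. All three share the same core, and they differ only in the groups carried on the benzyl ring.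

The compound still to be measured, compound 4, `CS(=O)(=O)c1ccc(CNc2cc(C(F)(F)F)cc3[nH]ncc23)c([N+](=O)O)c1`, comes from compound 2 by a single change: methylsulfonyl in place of methyl on an aromatic carbon, counted as methylsulfonyl in place of methyl on an aromatic carbon. Among the compounds with values here, no measured pair in this set shows this kind of change, so the size of the step cannot be read off from a neighbour. What the set does show is that compound 1, carrying a carboxylic acid on the benzyl ring, gives a higher number than compound 2. On that basis the step of a 1.5-fold higher number from compound 2 to compound 4 (0.16 log units; within the scatter) is expected to be modest and, if anything, towards a higher number, although a result within the scatter would not surprise. For compound 4 the expected value in this assay is 900 nM, with a likely range from 300 nM to 3000 nM.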

Compound 4, half-maximal inhibitory concentration: 790 nM
Beside the measured number, compound 4's estimate is 1.1-fold (0.06 log units) above it; the range from low to high includes it.
By their numbers in this assay, from the lowest: compound 3; then compounds 2 and 4 (each within the scatter of the next); then compound 1.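

In this assay, putting methylsulfonyl in place of methyl gives a 1.3-fold higher number from compound 2 to compound 4 (0.11 log units; within the scatter). Within the data shown here, this is the first pair in the set that differs in only one place, and it gives a direct reading of a single change on the shared core. At this aromatic carbon, para to a large group and meta to a group of 3 heavy atoms, going from 1 heavy atom to 4 heavy atoms and from 0 to 2 hydrogen-bond acceptors leaves the two compounds indistinguishable in this measurement, so this position accepts either group, and no measurement is available here to explain that result.

Still open, going by these compounds, is whether other groups at this same carbon, such as an amine, a methoxy group or a longer chain like ethyl, would also stay within the scatter of compound 2 or would produce a clear step. This single pair also cannot show whether methylsulfonyl would give a similar result at another carbon of the ring or on a compound with different neighbouring groups.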